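A few compounds are considered here, and "the series" means these few. Any claim that something is new, unique, unknown or untested is made for them only; others in the source may bear on it.

Measured so far in a functional assay on K562 cells (Homo sapiens) for antiproliferative activity, read by MTT assay; a lower number here means a stronger inhibitor, a higher number a weaker inhibitor:

- compound 1, `N#Cc1c(F)c(Cl)c(C(C(=O)c2ccccc2)=C2NCCN2)c(C#N)c1F`, gives 20.8 ug/mL
- compound 2, `N#Cc1c(F)c(F)c(C(C(=O)c2ccccc2)=C2NCCN2)c(C#N)c1F`, gives 19.6 ug/mL
- compound 3, `N#Cc1c(F)c(Cl)c(C(C(=O)c2ccc(F)cc2)=C2NCCCN2)c(C#N)c1F`, gives 1.8 ug/mL

Compound 1 and compound 2 share one core and differ in a single place: fluoro in place of chloro on an aromatic carbon. In this assay that change gave a 1.1-fold lower number from compound 1 to compound 2 (0.03 log units; within the scatter), so the two values are read as equivalent and no order is drawn between them.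

Compound 3 is built on a different core. The difference between the two cores is not broken down here. Compound 3 gives the lowest number of the three measured compounds, and its separation from both compound 1 and compound 2 lies beyond the scatter, so compound 3 is the strongest inhibitor among those measured.

Compound 4, `N#Cc1c(F)c(F)c(C(C(=O)c2ccc(F)cc2)=C2NCCCN2)c(C#N)c1F`, has not yet been measured. It differs from compound 3 by fluoro in place of chloro on an aromatic carbon. The surroundings of the changed position are described in the same words for both pairs, so this is the same change made once on the core of compound 1 and once on the core of compound 3.

Among the compounds with values here, the only precedent for the change is the step from compound 1 to compound 2, which stayed within the scatter. On that basis the step from compound 3 to compound 4 is expected to be a 1.1-fold lower number from compound 3 to compound 4 (0.02 log units; within the scatter), resting on the precedent a 1.1-fold lower number from compound 1 to compound 2 (0.03 log units; within the scatter). For compound 4 in this assay the estimated value is 1.7 ug/mL, expected to fall between 0.9 ug/mL and 3.5 ug/mL.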

Compound 4, half-maximal inhibitory concentration: 2.5 ug/mL
The estimate for compound 4 lay 1.5-fold (0.17 log units) below the measured number; the range from low to high includes it.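

In this assay, fluoro in place of chloro on the core of compound 3 gives a 1.4-fold higher number from compound 3 to compound 4 (0.14 log units; within the scatter), so compound 3 and compound 4 are read as equivalent and no order is drawn between them. This shows that, on the two cores at hand, exchanging chloro for fluoro on this aromatic carbon leaves the number within the scatter, but two pairs do not establish a rule for other cores, and a difference smaller than the scatter would not be visible in them. The two steps also agree with each other, so nothing here separates how the change behaves on one core from how it behaves on the other: the same change on two cores in this assay, a 1.1-fold lower number (0.03 log units; within the scatter) from compound 1 to compound 2 and a 1.4-fold higher number (0.14 log units; within the scatter) from compound 3 to compound 4, 1.5-fold (0.17 log units) apart, within the scatter of two such steps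

As far as these compounds go, only chloro and fluoro appear on this aromatic carbon, so it remains open whether bromo, methoxy, an amine or a longer chain at the same place would also leave the number unmoved on either core. The compounds shown also contain no pair that isolates any single difference between the two cores, so the contribution of each of those differences to the numbers in this assay remains unresolved.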